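This account rests on a few compounds, and the source may have more. Where it says the series, first, only, none or still open, it means among the compounds named here.

Notes on the series. Compound 1 `CCC(=O)N1c2ccc(-c3ccc(S(C)(=O)=O)cc3)cc2N(C(=O)c2ccco2)C[C@@H]1C` gives 550 nM in a functional assay on MV4-11 cells (Homo sapiens) for inhibition, read by luminescence and CellTiter-Glo, with a stated time of 72 h; a lower number here means a stronger inhibitor of growth, a higher number a weaker inhibitor of growth. Compound 2 `CC(=O)N1c2ccc(-c3ccc(S(C)(=O)=O)cc3)cc2N(C(=O)c2ccco2)C[C@@H]1C` gives 400 nM in this assay, and compound 3 `CC(=O)N1c2ccc(-c3ccccc3)cc2N(C(=O)c2ccco2)C[C@@H]1C` gives 350 nM in this assay. Compound 3 sits at the low end of the three numbers, yet its gaps to compound 2 and to compound 1 are both within the scatter. The two steps recorded so far are a 1.4-fold lower number from compound 1 to compound 2 (0.14 log units; within the scatter) and a 1.1-fold lower number from compound 2 to compound 3 (0.06 log units; within the scatter); neither moved the number beyond the scatter.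

Compound 4 `CC(=O)N1c2ccc(-c3cnn(C)c3)cc2N(C(=O)c2ccco2)C[C@@H]1C` differs from compound 3 by 1-methyl-1H-pyrazol-4-yl in place of phenyl on an aromatic carbon. Among the compounds with values here, no measured step exchanges the whole distal ring, so the change is only loosely covered. The closest guide is the step from compound 2 to compound 3, in which the methylsulfonyl on that ring was removed without a step beyond the scatter, and the step from compound 1 to compound 2 shows the same flatness for a change at the acyl end. On that basis a step in this assay of no more than the scatter is expected for compound 4, with the direction open. Compound 4 is therefore estimated at 500 nM, with a range from 170 nM to 1500 nM. This estimate means a step of a 1.4-fold higher number from compound 3 to compound 4 (0.15 log units; within the scatter) from compound 3 to compound 4.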

Compound 4, concentration for 50% growth inhibition: 210 nM
Beside the measured number, compound 4's estimate is 2.4-fold (0.38 log units) above it; measured number inside the range.
By their numbers in this assay, from the lowest: compounds 4, 3, 2 and 1 (each within the scatter of the next, the first and the last beyond it).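

The whole ring on this aromatic carbon can be exchanged, not only a substituent on it: in this assay, 1-methyl-1H-pyrazol-4-yl in place of phenyl gives a 1.7-fold lower number from compound 3 to compound 4 (0.22 log units; within the scatter), and in place of 4-(methylsulfonyl)phenyl it gives a 1.9-fold lower number from compound 2 to compound 4 (0.28 log units; within the scatter). A five-membered aromatic ring with 2 hetero atoms and 2 hydrogen-bond acceptors therefore reads the same, within the scatter, as the two six-membered aromatic rings of carbon only, which extends the flatness at this position to a change of ring type. No data at hand explain this result.

As far as these compounds go, whether a morpholine or a carboxylic acid on this aromatic carbon would also stay within the scatter remains open, as does the part played by the methyl of 1-methyl-1H-pyrazol-4-yl. The second amide of the shared core is the same in all four compounds, so these numbers say nothing about a change there.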